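This account rests on a few compounds, and the source may have more. Where it says the series, first, only, none or still open, it means among the compounds named here.

Values in a functional assay on Hs-578T cells (Homo sapiens) for inhibition, read by sulforhodamine B assay, with a stated time of 48 h (a lower number here means a stronger inhibitor of growth, a higher number a weaker inhibitor of growth), for the three measured compounds:

compound 1 `O=C(/C(=C\c1c(-c2ccccc2)[nH]c2ccccc12)S(=O)(=O)c1ccccc1)c1ccccc1`: compound 1 gives 39500 nM
compound 2 `COc1ccc(-c2[nH]c3ccc(OC)cc3c2/C=C(\C#N)S(=O)(=O)c2ccccc2)cc1`: compound 2 gives 538 nM
compound 3 `COc1ccc2[nH]c(-c3ccccc3)c(C=C(C#N)C#N)c2c1`: compound 3 gives 2400 nM

Compound 2 has the lowest of the three numbers; compound 3 sits above it by a margin beyond the scatter, and compound 1 much further above. Going by the values given here, no single-change step between measured compounds is available, so the weight of any one group cannot be read directly from these three.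

Compound 4 `COc1ccc(-c2[nH]c3ccccc3c2/C=C(\C#N)S(=O)(=O)c2ccccc2)cc1` differs from compound 2 in one place: hydrogen in place of methoxy on an aromatic carbon. A step of small size is expected, most likely towards a higher number, though it may also fall within the scatter. For compound 4 the estimate is 900 nM (range 300 nM to 3000 nM), which means an expected step of a 1.7-fold higher number from compound 2 to compound 4 (0.22 log units; within the scatter).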

Compound 4, concentration for 50% growth inhibition: 682 nM
The estimate for compound 4 lay 1.3-fold (0.12 log units) above the measured number; the range from low to high includes it.
By their numbers in this assay, from the lowest: compounds 2 and 4 (each within the scatter of the next); then compound 3; then compound 1.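

In this assay, going by these compounds alone, hydrogen in place of methoxy on this aromatic carbon gives a 1.3-fold higher number from compound 2 to compound 4 (0.10 log units; within the scatter) and so provides the first single-change reading. At this position, meta to a fused ring and para to a fused ring, the methoxy is not needed to keep the number within the scatter of compound 2. No available measurement bears on the reason for this result.

As far as these compounds go, whether an amine or a carboxylic acid on this carbon would give a step beyond the scatter remains open. From the compounds shown here alone, the weight of the second methoxy, shared by compound 2 and compound 4, also remains open.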